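Sulfonamide anilides: methyl to fluoro at the benzamide ring

The compounds below may be only part of what the source reports. "The series", "measured", "known", "first", "only" and "open" are said of these compounds alone.

Measured so far in a functional assay on HEK293 cells for agonist activity at probable G-protein coupled receptor 27 (Homo sapiens), read by a luciferase reporter and beta-arrestin recruitment, with a stated time of 10 min; a higher number here means that more compound is needed for the effect, a lower number that less compound is needed:
compound 1 `O=C(Nc1ccc(S(=O)(=O)Nc2ccccc2)cc1)c1ccc(Cl)nc1F`, 2290 nM;
compound 2 `O=C(Nc1ccc(S(=O)(=O)Nc2ccccc2)cc1)c1ccc(Cl)cc1Br`, 1020 nM;
compound 3 `Cc1cc(Br)ccc1C(=O)Nc1ccc(S(=O)(=O)Nc2ccccc2)cc1`, 851 nM.

Compound 3 gives the lowest number of the three, but it sits within the scatter of compound 2 (a 1.2-fold lower number from compound 2 to compound 3 (0.08 log units; within the scatter)), so the two cannot be ordered. Compound 1 lies clearly higher: a 2.7-fold lower number from compound 1 to compound 3 (0.43 log units; beyond the scatter) and a 2.2-fold lower number from compound 1 to compound 2 (0.35 log units; beyond the scatter).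

Compound 4 `O=C(Nc1ccc(S(=O)(=O)Nc2ccccc2)cc1)c1ccc(Br)cc1F` differs from compound 3 by fluoro in place of methyl on an aromatic carbon. Among the compounds with values here, no measured step exchanges these two groups at this position; the nearest comparison, a 1.2-fold lower number from compound 2 to compound 3 (0.08 log units; within the scatter), shows that the group ortho to the carbonyl can be changed between bromo and methyl with no shift beyond the scatter. Compound 1 carries fluoro at the same place but on a different ring, so its higher value cannot be assigned to the fluoro alone. A step of a 1.4-fold higher number from compound 3 to compound 4 (0.15 log units; within the scatter) is therefore expected, inside or barely beyond the scatter, with a slight lean toward a higher number. Compound 4 is estimated at 1200 nM in this assay, range 450 nM to 3200 nM.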

Compound 4, half-maximal effective concentration: 479 nM
For compound 4 the middle estimate is 2.5-fold (0.40 log units) above the measured one, and the stated range covers the measured number.
By their numbers in this assay, from the lowest: compounds 4, 3 and 2 (each within the scatter of the next, the first and the last beyond it); then compound 1.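

In this assay, fluoro in place of methyl on this aromatic carbon can now be read directly, and the step stays within the scatter (a 1.8-fold lower number from compound 3 to compound 4 (0.25 log units; within the scatter)), so the two groups cannot be ordered at this position. The 4-bromo-2-fluorophenyl group also separates from compound 2 (a 2.1-fold lower number from compound 2 to compound 4 (0.33 log units; beyond the scatter)) and from compound 1 (a 4.8-fold lower number from compound 1 to compound 4 (0.68 log units; beyond the scatter)), which shows that fluoro at this place is compatible with the low end of the series and does not alone account for the higher number of compound 1. No evidence is available that bears on these steps.

On these data alone, whether a methoxy, a nitrile or an amine at this position would fall within the same narrow band remains open. The compounds shown also leave open how much of the higher number of compound 1 goes with its ring and how much with its chloro group.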